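The compounds below may be only part of what the source reports. "The series", "measured", "known", "first", "only" and "open" are said of these compounds alone.

Working notes on the series. Compound 1 `CCCCCc1cc(C(C)=O)c(O)cc1OCCCCC#N` and compound 2 `C=CCc1cc(C(C)=O)c(O)cc1OCCCC#N` share a core and differ in more than one place. In an assay on isolated protein for inhibition of leukotriene B4 receptor 1 (Homo sapiens), tested at 10 uM (on this read-out higher numbers stand for more inhibition at the one concentration tested (going by the name of the read-out) and lower numbers for less inhibition), compound 1 gives 31%, while compound 2 gives 47%, the higher of the two numbers; the gap between them lies beyond the usual scatter. Compound 3 `C=CCc1cc(C(C)=O)c(O)cc1OCCCC` is not yet measured. Relative to compound 2 the change is methyl in place of cyano on a saturated chain carbon, three bonds along the chain from an oxygen on an aromatic ring. Going by the values given here, no measured pair isolates this change, so the expected step for compound 3 is small and uncertain in direction, with a slight loss considered more likely: a number 9 percentage points lower from compound 2 to compound 3 (within the scatter). Compound 3 is therefore estimated to give 38%, within a range from 20% to 55%.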

Compound 3, a percentage reported as inhibition, at one concentration (the size of the read-out at that concentration, not a potency): 32%
Compound 3: the middle estimate sits 6 percentage points above what was measured; measured number inside the range.
By their numbers in this assay, from the lowest: compounds 1 and 3 (each within the scatter of the next); then compound 2.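

In this assay, going by these compounds alone, methyl in place of cyano on a saturated chain carbon, three bonds along the chain from an oxygen on an aromatic ring, gives a number 15 percentage points lower from compound 2 to compound 3 (beyond the scatter) in the first comparison of the series that isolates one change. The group at this chain end therefore registers in the read-out, with the nitrile the higher of the two. No available data bear on the reason for this step. On these data alone, whether a carboxylic acid or an amine at the same chain end would match or exceed compound 2 remains open.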